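The source may hold more compounds than are shown below. What is called first, only, known or untested is meant among the compounds shown, and "the series" means these compounds.

Compound 3 `CCCCNCCC(=O)Nc1cccc2c1CN(C)CC2c1ccccc1` sits at the limit of a functional assay on the whole organism for inhibition of sodium-dependent dopamine transporter (Mus musculus); a higher number here means that more compound is needed for the effect, a lower number that less compound is needed: in this assay compound 3 gives > 60 mg/kg, which is a limit rather than a number (the limit of > 60 mg/kg in this assay, at which 1 of the 3 values shown sits). Among the compounds measured with the same core, compound 1 `CCCCOC(=O)Nc1cccc2c1CN(C)CC2c1ccccc1` gives 12 mg/kg and compound 2 `CC(C)NCC(=O)Nc1cccc2c1CN(C)CC2c1ccccc1` gives about 30 mg/kg in this assay. The steps are a 2.5-fold higher number from compound 1 to compound 2 (0.40 log units; beyond the scatter), an at least 5.0-fold higher number from compound 1 to compound 3 (0.69 log units; beyond the scatter) and an at least 2.0-fold higher number from compound 2 to compound 3 (0.30 log units; that floor lies within the scatter).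

Compound 4 `CN1Cc2c(NC(=O)CN3CCCCC3)cccc2C(c2ccccc2)C1` differs from compound 3 by piperidin-1-yl in place of (butylamino)methyl on a saturated chain carbon bound to a carbonyl carbon. This brings the chain back to the length seen in compound 2 while the nitrogen becomes part of a ring. The step from compound 2 to compound 3 bears most on this change: lengthening the chain moved the number to the limit, so shortening it again is expected to move it back toward the region of compound 2, giving an at least 2.0-fold lower number from compound 3 to compound 4 (0.30 log units; that floor lies within the scatter) in this assay. Compound 4 is therefore estimated at 30 mg/kg, within a range of 12 mg/kg to 90 mg/kg.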

Compound 4, dose for half-maximal effect: about 60 mg/kg
Compound 4: the middle estimate sits 2.0-fold (0.30 log units) below what was measured, and the stated range covers the measured number.
By their numbers in this assay, from the lowest: compound 1; then compounds 2 and 4 (each within the scatter of the next).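

Closing the nitrogen into a ring makes no readable difference at this position: with piperidin-1-yl in place of isopropylamino on a saturated chain carbon bound to a carbonyl carbon, this assay shows a 2.0-fold higher number from compound 2 to compound 4 (0.30 log units; within the scatter). The ring form also stays apart from the butoxy group of compound 1, with a 5.0-fold higher number from compound 1 to compound 4 (0.70 log units; beyond the scatter), so compounds 2 and 4 both give a higher number than compound 1 by a margin beyond the scatter. With piperidin-1-yl in place of (butylamino)methyl on a saturated chain carbon bound to a carbonyl carbon, this assay shows a number no higher from compound 3 to compound 4 (the limit leaves the size open). The size of this step stays open, because compound 3 gives a limit rather than a number: the limit of > 60 mg/kg in this assay, at which 1 of the 4 values shown sits.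

Going by these compounds, whether a pyrrolidine or morpholine ring would behave like piperidin-1-yl on this carbon remains open. So does the effect of piperidin-1-yl on the longer chain of compound 3, which would separate chain length from ring closure.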